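The compounds below may be only part of what the source reports. "The series", "measured", "known", "first", "only" and "open" are said of these compounds alone.

Compound 1 `Oc1cccc(-c2cc(-c3ccccc3)cc(-c3ccco3)n2)c1` and compound 2 `Oc1cccc(-c2cc(-c3ccccc3)cc(-c3ccncc3)n2)c1` share one core and differ only at a single aromatic carbon. In an assay on isolated protein for inhibition of DNA topoisomerase 1 (Homo sapiens), with a stated time of 30 min, tested at 20 uM (on this read-out higher numbers stand for a stronger effect at the one concentration tested and lower numbers for a weaker effect), compound 1 gives 0%, while compound 2 gives 25.4%. That single swap yields a number 25.4 percentage points higher from compound 1 to compound 2 (beyond the scatter), a change that lies beyond the usual scatter of repeated measurements. Going by the values given here, on the two numbers available, compound 2 therefore stands highest, with compound 1 as its only comparison.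

Compound 3 `Oc1cccc(-c2cc(-c3ccccc3)cc(-c3cccc(O)c3)n2)c1` is the next member and has not yet been measured. Relative to compound 2, the change is 3-hydroxyphenyl in place of pyridin-4-yl on an aromatic carbon. Among the compounds with values here, the one measured step, a number 25.4 percentage points higher from compound 1 to compound 2 (beyond the scatter), concerns a different pair of groups at this same carbon, so it shows only that this position can move the read-out by a modest amount; it does not show what the incoming group will do. With no closer comparison, the step of a number 10.4 percentage points lower from compound 2 to compound 3 (beyond the scatter) is expected to be small, possibly within the scatter, and more likely downward than upward. Compound 3 is thus estimated to give 15%, within a range from 0% to 40%.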

Compound 3, a percentage reported as inhibition, at one concentration (the size of the read-out at that concentration, not a potency): 10.5%
The estimate for compound 3 lay 4.5 percentage points above the measured number, and the stated range covers the measured number.
By their numbers in this assay, from the lowest: compound 1; then compound 3; then compound 2.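

In this assay, this carbon next to the ring nitrogen now carries three different groups, and the result is a graded series rather than a simple on-off contrast: 3-hydroxyphenyl gives a number 14.9 percentage points lower from compound 2 to compound 3 (beyond the scatter), yet still a number 10.5 percentage points higher from compound 1 to compound 3 (beyond the scatter). The six-membered ring of compound 3 therefore retains part of the gain seen with pyridin-4-yl, although the swap from compound 2 removes the ring nitrogen and adds a hydroxyl group in a single step, so the two changes cannot be told apart. No measurement is available here to explain why the three groups fall in this order.

A plain phenyl group at this carbon would separate the effect of the ring nitrogen from that of the hydroxyl group, while a 3-aminophenyl or 3-carboxyphenyl group would test whether another substituent at the same ring position reads closer to compound 2 or to compound 3. From the compounds shown here alone, it also remains open whether these differences at a single concentration would hold across a range of concentrations, and what changes at the two other aryl groups on the shared core would do.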